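The compounds below may be only part of what the source reports. "The series", "measured", "known", "first", "only" and "open" are said of these compounds alone.

The compounds share one small core and differ only in what sits on the urea nitrogen. Compound 1, `CCCCNC(=O)N1CC1C#N`, carries a butyl group there, and in a functional assay on L1210 cells (Mus musculus) for inhibition, read by MTT assay (a higher number here means a weaker inhibitor, a lower number a stronger inhibitor), compound 1 gives 12000 nM. Compound 2, `N#CC1CN1C(N)=O`, carries a hydrogen in the same position. In this assay compound 2 reaches only a limit, > 90000 nM. The step between them, an at least 7.5-fold higher number from compound 1 to compound 2 (0.87 log units; beyond the scatter), is known only as a bound because of the limit of > 90000 nM in this assay, at which 1 of the 2 values shown sits. Compound 2 therefore stands at the weak end of what has been measured, with no exact number of its own.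

Compound 3, `CNC(=O)N1CC1C#N`, differs from compound 2 by methyl in place of hydrogen on an amide-type nitrogen. Within the data shown here, the one measured step that bears on this change is an at least 7.5-fold higher number from compound 1 to compound 2 (0.87 log units; beyond the scatter), which ran toward weaker inhibition as the butyl chain was removed entirely. Restoring a single carbon is expected to recover part, though not all, of that loss, so in this assay the step from compound 2 to compound 3 is expected to be an at least 2.0-fold lower number from compound 2 to compound 3 (0.30 log units; that floor lies within the scatter). Compound 3 is accordingly estimated at 45000 nM, with a plausible range from 15000 nM to 150000 nM.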

Compound 3, half-maximal inhibitory concentration: 21000 nM
Beside the measured number, compound 3's estimate is 2.1-fold (0.33 log units) above it, and the stated range covers the measured number.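

In this assay, putting methyl in place of hydrogen on an amide-type nitrogen is enough to give a step of an at least 4.2-fold lower number from compound 2 to compound 3 (0.63 log units; beyond the scatter) and so shows that a single carbon at this position already matters. The size of this step remains a bound because compound 2 has no exact number of its own: the limit of > 90000 nM in this assay, at which 1 of the 3 values shown sits.
The further step, a 1.8-fold higher number from compound 1 to compound 3 (0.24 log units; within the scatter), replaces propyl with hydrogen on a saturated chain carbon bound to an amide-type nitrogen and stays within the scatter, so among these three compounds the clear difference lies between hydrogen and either chain, while methyl and butyl cannot be told apart.

What the compounds shown leave open is whether a chain longer than butyl, a benzyl group or a chain ending in an amine would move the number beyond the scatter from that of compound 1. They also keep the nitrile throughout, so they say nothing about how a carboxylic acid in its place would read.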